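A few compounds are considered here, and "the series" means these few. Any claim that something is new, unique, unknown or untested is made for them only; others in the source may bear on it.

Measured so far in an ADME assay on HEK293 cells (Homo sapiens) for cytotoxicity, read by luminescence, with a stated time of 72 h; on this read-out lower numbers stand for an effect already at smaller amounts and higher numbers for an effect only at larger amounts of compound:
- Compound 1 `CCOC(=O)c1c(-c2cccc(OC(C)C)c2)[nH]c2cc(OC)ccc2c1=O`: > 22000 nM (a limit)
- Compound 2 `CCOC(=O)c1c(-c2cccc(Oc3ccccc3)c2)[nH]c2cc(OC)ccc2c1=O`: > 22000 nM (a limit)
- Compound 3 `CCOC(=O)c1c(-c2cccc(C(F)(F)F)c2)[nH]c2cc(OC)ccc2c1=O`: > 22000 nM (a limit)

Compound 3 stands at > 22000 nM, which is a limit of the assay and not a number. Its place on the scale is the limit of > 22000 nM in this assay, at which 3 of the 3 values shown sit, so the three compounds cannot be ranked against one another.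

The next compound is compound 4 `CCOC(=O)c1c(-c2cccc(S(C)(=O)=O)c2)[nH]c2cc(OC)ccc2c1=O`, which keeps the shared core and changes one group of compound 3: methylsulfonyl in place of trifluoromethyl on an aromatic carbon. In words, methylsulfonyl comes in place of trifluoromethyl on an aromatic carbon.

The closest measured comparisons exchange the same group. They are a step that the two limits leave unreadable from compound 1 to compound 3 and a step that the two limits leave unreadable from compound 2 to compound 3. A third comparison, a step that the two limits leave unreadable from compound 1 to compound 2, alters that group further out. None of these steps has a readable size, so they offer no measured size or direction to carry over. Still, all three groups tried so far left the read-out at the same limit, and that is the basis for expecting compound 4 to behave alike.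

The expected step is a step that the limit leaves unreadable from compound 3 to compound 4, which means no change beyond the scatter and no particular direction. Another limit, rather than a number, is the most likely report.

The estimate for compound 4 is 25000 nM, with an expected range from 12000 nM to 50000 nM.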

Compound 4, half-maximal effective concentration: > 22000 nM
Compound 4: only a limit was reported; the forecaster's own chance of this, stated with the estimate: 85%; the middle value does not contradict the limit.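

No new step can be read for compound 4, compound 3, compound 2 or compound 1 in this assay, since each result is a limit and not a number: the limit of > 22000 nM in this assay, at which 4 of the 4 values shown sit.

The compounds shown leave open how these four compare with one another, and whether any other group at this place on the shared core would give a readable value.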